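This account rests on a few compounds, and the source may have more. Where it says the series, first, only, none or still open, it means among the compounds named here.

Compound 1 `Cc1ccccc1NC(=O)N[C@H](C)c1ccccc1` gives 100% in an ADME assay on the whole organism with Oryza sativa as the target, tested at 0.1 uM; on this read-out higher numbers stand for a weaker effect at the one concentration tested and lower numbers for a stronger effect.
Compound 2 `Cc1ccccc1NC(=O)N[C@@H](C)c1ccccc1` gives 100% in this assay.
Compound 3 `CCCc1ccc(NC(=O)N[C@@H](C)c2ccccc2)cc1` gives 97% in this assay.

All three of these numbers sit within the scatter of one another, so compound 2 cannot be told apart from compound 1 or compound 3 on the values shown. Going by the values given here, the only step among the measured compounds, no change at the digits printed from compound 1 to compound 2 (within the scatter), shows no change, which fits with the fact that compounds 1 and 2 differ only in the configuration as drawn. Compound 3 carries a different group on its aromatic ring than compound 2, yet its value lies within the scatter of the value of compound 2.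

The next compound, compound 4 `C[C@H](NC(=O)Nc1ccccc1C(C)(C)C)c1ccccc1`, differs from compound 2 in one place: tert-butyl in place of methyl on an aromatic carbon. Among the compounds with values here, no measured step changes a substituent on that ring in this way, so the measured steps give little guidance beyond the observation that every change seen so far left the read-out where it was. On that basis the step of a number 3 percentage points lower from compound 2 to compound 4 (within the scatter) is expected to stay within the scatter. The value of compound 4 in this assay is therefore estimated at 97%, with a range from 85% to 100%.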

Compound 4, a percentage reported as activity, at one concentration (the size of the read-out at that concentration, not a potency): 101%
Beside the measured number, compound 4's estimate is 4 percentage points below it; measured number above the stated range.
By their numbers in this assay, from the lowest: compounds 3, 1, 2 and 4 (each within the scatter of the next).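

Putting tert-butyl in place of methyl on this aromatic carbon gives a number 1 percentage points higher from compound 2 to compound 4 (within the scatter) in this assay. Going by these compounds alone, this is the first measured change at this place, ortho to a large group, and it shows that a group of 4 heavy atoms can stand where 1 stood without the read-out moving beyond the scatter, so the larger group brings no stronger effect that can be seen at the one concentration tested. Nothing at hand gives a reason for this result.

From the compounds shown here alone, it remains open whether a group of another kind on this carbon, such as an amine, a carboxylic acid or a methoxy group, would move the number beyond the scatter. Going by these compounds, it also remains open whether a higher concentration would separate compound 2 from compound 4.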